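A Thiocarbamate Variant on the Shared Core

The source may hold more compounds than are shown below. What is called first, only, known or untested is meant among the compounds shown, and "the series" means these compounds.

Compound 1 `CCOC(=O)N1CCC(Oc2ncnc3c2CCN3c2ccc(S(C)(=O)=O)cc2F)CC1` and compound 2 `CC(C)COC(=O)N1CCC(Oc2ncnc3c2CCN3c2ccc(S(C)(=O)=O)cc2F)CC1` share one core and differ only in the group on the carbamate oxygen. Going by the values given here, in a functional assay on CHO-K1 cells with Glucose-dependent insulinotropic receptor (Homo sapiens) as the target, read by a luciferase reporter, with a stated time of 5 h (a lower number here means a smaller maximal response, a higher number a larger maximal response), compound 1 gives 135%, whereas compound 2 gives 94%, the lower of the two numbers known; that step is a number 41 percentage points lower from compound 1 to compound 2 (beyond the scatter). Compound 3 `CSC(=O)N1CCC(Oc2ncnc3c2CCN3c2ccc(S(C)(=O)=O)cc2F)CC1` carries the change (methylsulfanyl in place of isobutoxy on a carbonyl carbon). Among the compounds with values here, the single measured step is only loosely related, since it enlarged the group while this change shrinks it and swaps the atom on the carbonyl. Compound 3 is therefore expected to rise by a number 21 percentage points higher from compound 2 to compound 3 (beyond the scatter), to an estimated 115%, within 80% to 150%.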

Compound 3, largest response reached (reported as percent of maximum), in percent of the reference or control that the assay uses: 135%
Estimate against measurement, compound 3: 20 percentage points below, within the range that was stated.
By their numbers in this assay, from the lowest: compound 2; then compounds 1 and 3 (each within the scatter of the next).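

In this assay exchanging isobutoxy for methylsulfanyl gives a number 41 percentage points higher from compound 2 to compound 3 (beyond the scatter) and exchanging ethoxy for methylsulfanyl gives no change at the digits printed from compound 1 to compound 3 (within the scatter) at the same carbonyl carbon. This place therefore accepts a group attached through sulfur with a maximal response matching that of the ethoxy compound, and among the three groups only isobutoxy stands apart beyond the scatter. Nothing available explains why these groups differ in this way. Going by these compounds, whether an amine on this carbonyl carbon, or a longer chain on the sulfur, would hold the same response remains open.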